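Second chlorine on the purine core: expected cytotoxicity

This account rests on a few compounds, and the source may have more. Where it says the series, first, only, none or still open, it means among the compounds named here.

Measured compounds:
compound 1, `ClCc1cccc(Cn2cnc3c(Cl)ncnc32)c1`, 29500 nM
compound 2, `ClCc1ccc(Cn2cnc3nc(Cl)nc(Cl)c32)cc1`, 5880 nM
compound 3, `ClCc1ccccc1Cn1cnc2ncnc(Cl)c21`, 46800 nM

Three purine-based compounds were tested in a functional assay on SF-295 cells (Homo sapiens) for cytotoxicity, read by sulforhodamine B assay, with a stated time of 48 h; on this read-out lower numbers stand for higher toxicity in this test and higher numbers for lower toxicity in this test. Compound 3 gives the highest of the three numbers; its nearest neighbour is compound 1, whose value lies within the scatter of compound 3, so the two cannot be told apart. Compound 2 stands well apart, with a markedly lower number, beyond the scatter. Compound 2 differs from compound 3 in more than one place, so its lower number cannot be tied to any single change.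

Compound 4, `ClCc1ccccc1Cn1cnc2nc(Cl)nc(Cl)c21`, is the next structure to be measured. It differs from compound 3 by chloro in place of hydrogen on an aromatic carbon. Going by the values given here, no pair of measured compounds differs by this change alone, so the size of the step in this assay is uncertain. The dichloro compound 2 showing the lowest number hints that the second chloro group may lower the number, but this rests on one compound that also carries other differences. A modest move toward a lower number is expected, a 3.1-fold lower number from compound 3 to compound 4 (0.49 log units; beyond the scatter). Compound 4 is estimated at 15000 nM, within a range from 5000 nM to 45000 nM.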

Compound 4, concentration lethal to 50% of the cells: 61700 nM
For compound 4 the middle estimate is 4.1-fold (0.61 log units) below the measured one; measured number above the stated range.
By their numbers in this assay, from the lowest: compound 2; then compounds 1, 3 and 4 (each within the scatter of the next, the first and the last beyond it).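

In this assay, going by these compounds alone, this pair gives the first reading of a single change on the shared core: a 1.3-fold higher number from compound 3 to compound 4 (0.12 log units; within the scatter), so chloro in place of hydrogen on this aromatic carbon, between two ring nitrogen atoms, has no measurable effect here. The second chloro group alone therefore does not go with a low number: compound 4 carries the same two chloro groups as compound 2, yet compound 2 gives 5880 nM and compound 4 gives 61700 nM. No supporting measurement bears on why this step is so small.

From the compounds shown here alone, it remains open whether an amine or a methoxy group on this same carbon would shift the number. Also open, going by these compounds, is whether chloro in place of hydrogen would stay this quiet with the chloromethyl group placed as in compound 1.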